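The source may report more compounds than this note shows. Statements on the series, on what has been measured and on what is new or still open speak of the compounds shown alone.

Compound 1 `O=C1N=C(N2CCOCC2)CN1Cc1ccccc1`: in a functional assay on the whole organism (strain NMRI BR) with Mus musculus as the target (a lower number here means that less compound is needed, a higher number that more compound is needed for the effect), compound 1 gives > 300 mg/kg, a limit of the assay rather than a number.
Compound 2 `O=C1N=C(N2CCOCC2)CN1Cc1ccccc1Cl`: in this assay compound 2 gives > 300 mg/kg, again a limit.
Compound 3 `O=C1N=C(N2CCOCC2)CN1c1ccc(Cl)c(Cl)c1`: in this assay compound 3 gives > 300 mg/kg, also a limit.

All three measured compounds share the same core and differ only in the group attached to its nitrogen. None of them produced a measurable dose; every value sits at the limit of > 300 mg/kg in this assay, at which 3 of the 3 values shown sit. Compound 2 therefore stands only at a limit, and no number places it above or below compound 1 or compound 3. Within the data shown here, the single step that pairs two measured compounds, a step that the two limits leave unreadable from compound 1 to compound 2, runs from one limit to another and cannot be read in size or direction.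

The unmeasured compound 4 `O=C1N=C(N2CCOCC2)CN1Cc1c(Cl)cccc1Cl` arises from compound 2 by chloro in place of hydrogen on an aromatic carbon. Among the measured compounds shown here, the one measured step of the same kind, adding a chloro group to the ring of compound 1, is unreadable, so no size can be taken from it, and nothing here suggests a shift beyond the scatter. Compound 4 is therefore expected to give about 450 mg/kg, within 150 mg/kg to 1500 mg/kg, most likely reported as another limit. The step this estimate implies, a step that the limit leaves unreadable from compound 2 to compound 4, is expected to be none beyond the scatter.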

Compound 4, dose for half-maximal effect: > 300 mg/kg
Compound 4 ended at the assay's limit (the forecaster's own chance of this, stated with the estimate: 85%); the middle value is on the limit's open side.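

Compound 2 and compound 4 both end at a limit of the assay, so the step between them cannot be read in size or direction. The same holds for every value shown: the limit of > 300 mg/kg in this assay, at which 4 of the 4 values shown sit.

The compounds shown leave open what dose of each would give the half-maximal effect in this assay, and whether adding chloro groups changes that dose at all.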